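This account rests on a few compounds, and the source may have more. Where it says the series, first, only, none or still open, it means among the compounds named here.

Measured so far in an ADME assay on microsomes from liver (Mus musculus, strain CD1) for metabolic stability, read by HPLC, with a stated time of 30 min, tested at 1 uM (a higher number here means faster removal of the compound, a lower number slower removal), for two compounds
Compound 1 (`Cn1cc2c(NS(=O)(=O)c3ccc(Br)cc3)cccc2n1`) gives 6.3 mL.min-1.g-1
Compound 2 (`O=S(=O)(Nc1c(N2CCCC2)ccc2ncccc12)c1ccc(Br)cc1`) gives 27 mL.min-1.g-1

Compound 1 stands lowest of these two numbers, and compound 2 lies higher by a margin beyond the usual scatter. Compound 3 (`Cn1cc2c(NS(=O)(=O)c3ccc(Br)cc3)c(N3CCCC3)ccc2n1`), not yet measured, keeps the core of compound 1 and takes pyrrolidin-1-yl in place of hydrogen on an aromatic carbon, ortho to a large group. Going by the values given here, no measured pair shows this change on its own, so any forecast rests on thin ground. Among the compounds with values here, the only guide is compound 2, which also carries pyrrolidin-1-yl on a different core and gives 27 mL.min-1.g-1, so a rise beyond the scatter is expected. The expected step is a 2.9-fold higher number from compound 1 to compound 3 (0.46 log units; beyond the scatter), a moderate one. In this assay the estimated value for compound 3 is 18 mL.min-1.g-1 (range 9 mL.min-1.g-1 to 40 mL.min-1.g-1).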

Compound 3, intrinsic clearance in microsomes: 33 mL.min-1.g-1
Beside the measured number, compound 3's estimate is 1.8-fold (0.26 log units) below it; the measured number falls inside the stated range.
By their numbers in this assay, from the lowest: compound 1; then compounds 2 and 3 (each within the scatter of the next).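

In this assay, pyrrolidin-1-yl in place of hydrogen on an aromatic carbon, ortho to a large group, gives a 5.2-fold higher number from compound 1 to compound 3 (0.72 log units; beyond the scatter). Going by these compounds alone, this is the first time the change can be read on its own, with the rest of the structure held constant, and the step is modest but beyond the scatter. It ties faster removal to this one substitution at this position, but nothing available explains the rise.

Going by these compounds, it remains open whether another amine at the same place, such as dimethylamino or morpholin-4-yl, or a plain methoxy group, would bring a step of similar size. On these data alone, it also remains open whether pyrrolidin-1-yl would bring a comparable step on the core of compound 2.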